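Swapping a ring bearing two oxygens for cyclohexyl

The source may report more compounds than this note shows. Statements on the series, on what has been measured and on what is new or still open speak of the compounds shown alone.

Measured compounds:
compound 1 `c1ccc(-c2nc(SCC3OCCCO3)[nH]c2-c2ccccc2)cc1` — 180 nM
compound 2 `c1ccc(-c2nc(SCCC3OCCCO3)[nH]c2-c2ccccc2)cc1` — 730 nM

Compound 2 gives the highest number of the two in an assay on microsomes from liver for inhibition of sterol O-acyltransferase 1 (Rattus norvegicus); on this read-out lower numbers stand for stronger inhibition and higher numbers for weaker inhibition; its nearest neighbour is compound 1, and the step of a 4.1-fold higher number from compound 1 to compound 2 (0.61 log units; beyond the scatter) lies beyond the scatter. Compound 3 `c1ccc(-c2nc(SCC3CCCCC3)[nH]c2-c2ccccc2)cc1` has not yet been measured. It differs from compound 2 in one place: a group of 6 heavy atoms (6 carbon; one six-membered non-aromatic ring of carbon only) in place of a group of 7 heavy atoms (5 carbon, 2 oxygen; one six-membered non-aromatic ring with 2 hetero atoms), on a saturated chain carbon bound to a sulfur. Within the data shown here, the only measured step, from compound 1 to compound 2, exchanged groups at the same place on the chain bound to the sulfur, and it was modest. Among the measured compounds shown here, no measured pair exchanges a ring with two oxygens for a ring of carbon only, so the direction of the change for compound 3 rests on little. Since compound 1 reads 180 nM with a smaller group at this place, a moderately lower number is expected for compound 3, with a wide range: compound 3 is estimated at 250 nM (range 80 nM to 900 nM), an expected step of a 2.9-fold lower number from compound 2 to compound 3 (0.47 log units; beyond the scatter).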

Compound 3, half-maximal inhibitory concentration: 100 nM
Estimate against measurement, compound 3: 2.5-fold (0.40 log units) above; the measured number falls inside the stated range.
By their numbers in this assay, from the lowest: compounds 3 and 1 (each within the scatter of the next); then compound 2.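

In this assay, the step of a 1.8-fold lower number from compound 1 to compound 3 (0.26 log units; within the scatter) shows that on a saturated chain carbon bound to a sulfur, the two oxygens of the ring can be replaced by carbon without a change beyond the scatter, so cyclohexyl, with no hydrogen-bond acceptors, serves as well here as the ring it replaces. The larger step of a 7.3-fold lower number from compound 2 to compound 3 (0.86 log units; beyond the scatter) exchanges the ring and shortens the group in one move, so it cannot be credited to either alone. Nothing at hand explains these numbers.

As far as these compounds go, it remains open whether cyclohexyl on a longer chain would show the same loss as the step of a 4.1-fold higher number from compound 1 to compound 2 (0.61 log units; beyond the scatter). Equally open, from the compounds shown here alone, is how an amine or a carboxylic acid in place of the ring would read in this assay.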